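This account rests on a few compounds, and the source may have more. Where it says the series, first, only, none or still open, it means among the compounds named here.

For the measured compounds named here, the three compounds measured so far share one core and differ in the ester and in the pyridyl ring. Compound 1 `CC1=NC(C)=C([N+](=O)[O-])C(c2ccccn2)/C1=C(\O)OC(C)(C)C` carries a tert-butyl ester and a pyridin-2-yl ring; in a functional assay (cardiac atrium) for agonist activity, with Cavia porcellus as the target (a higher number here means that more compound is needed for the effect, a lower number that less compound is needed), compound 1 gives 1810000 nM. Compound 2 `CO/C(O)=C1\C(C)=NC(C)=C([N+](=O)[O-])C1c1cccnc1` carries a methyl ester and a pyridin-3-yl ring, and in this assay compound 2 gives 70000 nM. Compound 3 `CCO/C(O)=C1\C(C)=NC(C)=C([N+](=O)[O-])C1c1cccnc1` differs from compound 2 only in the ester, and in this assay compound 3 gives 8840 nM. Going by the values given here, the one step that can be followed is a 7.9-fold lower number from compound 2 to compound 3 (0.90 log units; beyond the scatter). Compound 3 thus stands lowest of the three numbers, nearest to compound 2 and furthest from compound 1.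

Among the compounds with values here, compound 4 `CCO/C(O)=C1\C(C)=NC(C)=C([N+](=O)[O-])C1c1ccccn1` is the next compound. pyridin-2-yl in place of pyridin-3-yl on a saturated ring carbon No measured step isolates this change: compound 1 also carries pyridin-2-yl, but it differs from compound 3 in the ester as well, so its two values show only that the pyridin-2-yl compound gives a far higher number than the pyridin-3-yl compound. On that basis compound 4 is expected to give a clearly higher number than compound 3, the expected step being a 17-fold higher number from compound 3 to compound 4 (1.23 log units; beyond the scatter). For compound 4 the estimate in this assay is 150000 nM, with a range from 30000 nM to 800000 nM.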

Compound 4, half-maximal effective concentration: 22800 nM
Estimate against measurement, compound 4: 6.6-fold (0.82 log units) above; measured number outside the range, below it.
By their numbers in this assay, from the lowest: compound 3; then compound 4; then compound 2; then compound 1.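

With the ethyl ester held fixed, the change on the saturated ring carbon can now be read alone: in this assay pyridin-2-yl in place of pyridin-3-yl gives a 2.6-fold higher number from compound 3 to compound 4 (0.41 log units; beyond the scatter), so this position responds to the change of ring, though only modestly. Compound 4 also pairs with compound 1, which carries the same pyridin-2-yl ring, and ethyl in place of tert-butyl gives a 79-fold lower number from compound 1 to compound 4 (1.90 log units; beyond the scatter), a much larger step than the ring change, so the very high number of compound 1 rests more on its tert-butyl ester than on its pyridin-2-yl ring. No measurement at hand accounts for either step.

From the compounds shown here alone, the ring step has been read with the ethyl ester only, so whether it keeps its size alongside a methyl or tert-butyl ester remains open. Also open, going by these compounds, is where a pyridin-4-yl ring at this position, or a longer chain such as n-propyl on the ester oxygen, would fall in this order.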